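Series notes: thioether replacement at the ketone-bearing chain carbon

The source may hold more compounds than are shown below. What is called first, only, known or untested is meant among the compounds shown, and "the series" means these compounds.

Compound 1 `CCOC(=O)c1c(C)noc1OCC(=O)[C@H](CC(=O)O)NC(=O)[C@@H](NC(=O)COc1cccc2ccccc12)C(C)C` reaches only the limit > 200000 nM in a functional assay on Jurkat cells (Homo sapiens) for inhibition; on this read-out lower numbers stand for stronger inhibition and higher numbers for weaker inhibition. Compound 2 `CC(C)[C@H](NC(=O)COc1cccc2ccccc12)C(=O)N[C@@H](CC(=O)O)C(=O)CSc1nnnn1C` likewise gives only the limit > 200000 nM in this assay. The step that the two limits leave unreadable from compound 1 to compound 2 is therefore unreadable, and both values sit at the limit of > 200000 nM in this assay, at which 2 of the 2 values shown sit. Compound 3 `CC(C)[C@H](NC(=O)COc1cccc2ccccc12)C(=O)N[C@@H](CC(=O)O)C(=O)CSc1nc2ccccc2[nH]1` carries 1H-benzimidazol-2-yl in place of 1-methyl-1H-tetrazol-5-yl on a sulfur. Among the compounds with values here, no measured step bears on this change; the only comparison available is the unreadable one from compound 1 to compound 2. Compound 3 is thus expected near the same limit, with the step of a number no higher from compound 2 to compound 3 (the limit leaves the size open) estimated as negligible. The estimate for compound 3 in this assay is 200000 nM, within 40000 nM to 1000000 nM.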

Compound 3, half-maximal inhibitory concentration: > 200000 nM
Compound 3: a limit, no number; the forecaster's own chance of this, stated with the estimate: 70%; the middle value sits exactly at the limit.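

No step can be read among compound 1, compound 2 and compound 3, since all three stay at a single limit: the limit of > 200000 nM in this assay, at which 3 of the 3 values shown sit.

The compounds shown leave open whether exchanging these groups changes inhibition at all in this assay.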